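This account rests on a few compounds, and the source may have more. Where it says the series, first, only, none or still open, it means among the compounds named here.

Of the compounds shown here, two that share one core have been measured in an assay on isolated protein for displacement of a labelled ligand from melanin-concentrating hormone receptor 1 (Homo sapiens); a higher number here means a weaker inhibitor, a lower number a stronger inhibitor. Compound 1 `Cc1cc(N)c2cc(NC(=O)/C=C/c3ccc(C(F)(F)F)cc3)ccc2n1` carries a methyl group on an aromatic carbon of the core and gives 8 nM. Compound 2 `CCC(C)c1cc(N)c2cc(NC(=O)/C=C/c3ccc(C(F)(F)F)cc3)ccc2n1` carries a sec-butyl group at the same place and gives 0.3 nM. Within the data shown here, the single measured step, a 27-fold lower number from compound 1 to compound 2 (1.43 log units; beyond the scatter), lies well beyond the scatter. Among the two values shown, compound 2 has the lower one, with compound 1 the only neighbour at a much higher number.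

Compound 3 `Nc1cc(-c2ccccc2)nc2ccc(NC(=O)/C=C/c3ccc(C(F)(F)F)cc3)cc12` has not yet been measured in this assay. Its structure differs from compound 2 in one place: phenyl in place of sec-butyl on an aromatic carbon. Among the measured compounds shown here, the only step that bears on this change is the one from methyl to sec-butyl, which was large and went toward a lower number; it shows that a move from a smaller to a larger group at this position was followed by a lower number, but it says nothing about an aromatic ring there. The expectation is that compound 3 keeps most of that gain, with an estimated step of a 2.0-fold higher number from compound 2 to compound 3 (0.30 log units; within the scatter). Compound 3 is therefore expected to give about 0.6 nM in this assay, with a range from 0.1 nM to 3 nM.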

Compound 3, half-maximal inhibitory concentration: 18.5 nM
For compound 3 the middle estimate is 31-fold (1.49 log units) below the measured one; measured number above the stated range.
By their numbers in this assay, from the lowest: compound 2; then compound 1; then compound 3.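

In this assay, replacing sec-butyl with phenyl gives a 62-fold higher number from compound 2 to compound 3 (1.79 log units; beyond the scatter), so the gain seen with sec-butyl does not carry over to every larger group on this aromatic carbon. Phenyl also compares poorly with the small methyl group, with a 2.3-fold higher number from compound 1 to compound 3 (0.36 log units; beyond the scatter), a modest change that is still beyond the scatter. Across these three compounds, a simple rule that a larger group gives a lower number therefore fails, with compound 3 as the exception, and nothing here explains why the aromatic ring and the branched chain differ so sharply.

On these data alone, it remains open whether the low number of compound 2 belongs to sec-butyl alone or to open carbon chains more broadly, which an isopropyl group, a tert-butyl group or a straight butyl chain on the same carbon could help to show. A cyclohexyl ring would separate the presence of a ring from its aromatic character, while a pyridine ring or a phenyl ring bearing a fluorine atom would show whether other aromatic rings at this position give similarly high numbers.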